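The source may report more compounds than this note shows. Statements on the series, on what has been measured and on what is new or still open speak of the compounds shown alone.

Compound 3 `NC(=O)CNc1cc(=O)oc2cc(OCc3cccc(Cl)c3)ccc12` gives 49 nM in an assay on brain (strain Sprague-Dawley) for inhibition of Amine oxidase [flavin-containing] B (Rattus norvegicus), read by spectrophotometry (a higher number here means a weaker inhibitor, a lower number a stronger inhibitor), the second highest of the three numbers recorded there. Compound 2 `O=c1cc(CCCl)c2ccc(OCc3cccc(Cl)c3)cc2o1` gives 12.9 nM, and compound 1 `O=C(O)COc1cc(=O)oc2cc(OCc3cccc(Cl)c3)ccc12` gives 31600 nM. Compound 4 `O=C(CCl)Nc1cc(=O)oc2cc(OCc3cccc(Cl)c3)ccc12` is compound 3 with (chloromethyl)carbonyl in place of carbamoylmethyl on a nitrogen on an aromatic ring. The step that bears most closely is a 3.8-fold higher number from compound 2 to compound 3 (0.58 log units; beyond the scatter), a modest change; the step of a 640-fold lower number from compound 1 to compound 3 (2.81 log units; beyond the scatter) was large but replaced a different group at the same site. Since both compound 3 and compound 4 carry a chloro-free or chloro-bearing two-carbon group on that ring nitrogen, no step beyond the scatter is expected, with a 1.4-fold lower number from compound 3 to compound 4 (0.15 log units; within the scatter) as the estimate. Compound 4 is therefore expected to give about 35 nM, between 8 nM and 150 nM.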

Compound 4, half-maximal inhibitory concentration: 398 nM
Beside the measured number, compound 4's estimate is 11-fold (1.06 log units) below it; the measured number lies above the stated range.
By their numbers in this assay, from the lowest: compound 2; then compound 3; then compound 4; then compound 1.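

On the nitrogen on an aromatic ring, the position proved sensitive to the nature of the group in this assay: (chloromethyl)carbonyl in place of carbamoylmethyl weakened inhibition (an 8.1-fold higher number from compound 3 to compound 4 (0.91 log units; beyond the scatter)). The ((chloromethyl)carbonyl)amino group also fell well short of 2-chloroethyl (a 31-fold higher number from compound 2 to compound 4 (1.49 log units; beyond the scatter)), yet remained far stronger than carboxymethoxy (a 79-fold lower number from compound 1 to compound 4 (1.90 log units; beyond the scatter)). Nothing available explains these shifts. The compounds shown leave open whether an acetyl group or a longer chloroalkyl carbonyl chain on that nitrogen would match compound 4, and so whether the chlorine itself matters here.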